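Swapping the aryl group on the ring nitrogen

This account rests on a few compounds, and the source may have more. Where it says the series, first, only, none or still open, it means among the compounds named here.

In a functional assay on HT-29 cells (Homo sapiens) for antiproliferative activity, read by MTT assay, with a stated time of 72 h (a lower number here means a stronger inhibitor, a higher number a weaker inhibitor), compound 1 `O=C(Nc1ccc(Oc2ccnc3[nH]ccc23)c(F)c1)c1cc2cccnc2n(-c2ccc(F)c(Cl)c2)c1=O` gives 310 nM. Compound 2 `Cn1ccc2c(Oc3ccc(NC(=O)c4cc5cccnc5n(-c5ccc(F)c(Cl)c5)c4=O)cc3)ccnc21` gives 1210 nM in this assay, and compound 3 `COc1ccc(-n2c(=O)c(C(=O)Nc3ccc(Oc4ccnc5c4ccn5C)c(F)c3)cc3cccnc32)cc1` gives 1290 nM. Compound 3 therefore stands highest of the three numbers, close to compound 2 and well beyond the scatter away from compound 1.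

Compound 4 `Cn1ccc2c(Oc3ccc(NC(=O)c4cc5cccnc5n(-c5ccc(F)c(Cl)c5)c4=O)cc3F)ccnc21` differs from compound 3 by one change: 3-chloro-4-fluorophenyl in place of 4-methoxyphenyl on an aromatic nitrogen. Compounds 1 and 2 already carry this 3-chloro-4-fluorophenyl group, and compound 1 is the strongest inhibitor shown, so a moderate drop in the number is expected for compound 4. The step from compound 3 to compound 4 in this assay is estimated as a 1.8-fold lower number from compound 3 to compound 4 (0.27 log units; within the scatter), modest but possibly beyond the scatter. For compound 4 the expected value is 700 nM, with a range from 250 nM to 2000 nM.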

Compound 4, half-maximal inhibitory concentration: 2460 nM
Estimate against measurement, compound 4: 3.5-fold (0.55 log units) below, and the stated range ends below it.
By their numbers in this assay, from the lowest: compound 1; then compounds 2, 3 and 4 (each within the scatter of the next, the first and the last beyond it).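

In this assay, 3-chloro-4-fluorophenyl in place of 4-methoxyphenyl on the aromatic nitrogen brings no gain, since a 1.9-fold higher number from compound 3 to compound 4 (0.28 log units; within the scatter) stays within the scatter; this group alone therefore does not give a low number. Two other changes do raise the number: fluoro in place of hydrogen on an aromatic carbon gives a 2.0-fold higher number from compound 2 to compound 4 (0.31 log units; beyond the scatter) here, and methyl in place of hydrogen on an aromatic nitrogen gives a 7.9-fold higher number from compound 1 to compound 4 (0.90 log units; beyond the scatter) here. Nothing available explains these steps. Still open, going by these compounds, is how an unsubstituted phenyl or a morpholinoethyl chain on that aromatic nitrogen would score.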